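A few compounds are considered here, and "the series" means these few. Any claim that something is new, unique, unknown or untested is made for them only; others in the source may bear on it.

The study looks at three ureas on a shared core, compound 1 `Cc1cc(NC(=O)Nc2ccc(C)c(Cl)c2)c2ccccc2n1`, compound 2 `Cc1cc(NC(=O)Nc2ccc(N(C)C)cc2)c2ccccc2n1` and compound 3 `Cc1cc(NC(=O)Nc2ccc([N+](=O)[O-])c(C(F)(F)F)c2)c2ccccc2n1`, tested in an ADME assay on HepG2 cells (Homo sapiens) for cytotoxicity, with a stated time of 72 h; on this read-out higher numbers stand for an effect only at larger amounts of compound and lower numbers for an effect already at smaller amounts. In this assay compound 1 reaches only the limit of the assay, > 25000 nM. Compound 2 likewise gives only a limit, > 25000 nM. Compound 3 also sits at a limit, > 25000 nM. Compound 2 thus stands where every shown value stands, at the limit of > 25000 nM in this assay, at which 3 of the 3 values shown sit, with no number to set it apart. Compound 4 `COc1ccc(NC(=O)Nc2cc(C)nc3ccccc23)cc1` is not yet measured; it differs from compound 2 by methoxy in place of dimethylamino on an aromatic carbon. With nothing but limits shown, the expected step is none beyond the scatter. For compound 4 the estimate is 30000 nM, between 15000 nM and 60000 nM. This estimate means an expected step that the limit leaves unreadable from compound 2 to compound 4, so compound 4 is expected to reach again only a limit.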

Compound 4, half-maximal effective concentration: > 25000 nM
Compound 4: only a limit was reported; the forecaster's own chance of this, stated with the estimate: 85%; the middle value lies beyond the limit too.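

No step can be read between compound 2 and compound 4, since both give only a limit: the limit of > 25000 nM in this assay, at which 4 of the 4 values shown sit. In this assay the compounds shown leave open at what concentration any of them would show an effect.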